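The source may report more compounds than this note shows. Statements on the series, on what has been measured and on what is new or still open speak of the compounds shown alone.

Compound 1 `CC(C)(C)NCc1c(C(=O)O)nn(-c2ccc(Cl)cc2)c1-c1ccc(Cl)cc1`: > 599000 nM
Compound 2 `CC(C)(C)NCc1c(C(=O)O)nn(-c2ccc(Cl)cc2)c1-c1ccccc1`: > 652000 nM
Compound 3 `Cc1ccc(-c2c(CNC(C)(C)C)c(C(=O)O)nn2-c2ccc(Cl)cc2)cc1`: > 629000 nM

Compound 3 reaches only a limit in a functional assay on 786-0 cells (Homo sapiens) for inhibition, read by sulforhodamine B assay, with a stated time of 48 h (a higher number here means a weaker inhibitor of growth, a lower number a stronger inhibitor of growth), > 629000 nM. The entries for compound 1 and compound 2 are limits as well, so no measured number exists in this set.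

Compound 4 `COc1ccc(-c2c(CNC(C)(C)C)c(C(=O)O)nn2-c2ccc(Cl)cc2)cc1` differs from compound 3 at one place: methoxy in place of methyl on an aromatic carbon. This is methoxy in place of methyl, 4-methylphenyl to 4-methoxyphenyl.

The measured steps at this place are a step that the two limits leave unreadable from compound 1 to compound 2, a step that the two limits leave unreadable from compound 1 to compound 3 and a step that the two limits leave unreadable from compound 2 to compound 3. None has a readable size, so no step beyond the scatter and no direction is expected in this assay.

The expected change is an at least 1.0-fold lower number from compound 3 to compound 4 (0.02 log units; that floor lies within the scatter).

For compound 4 the estimate is 600000 nM, with an expected range of 300000 nM to 1000000 nM.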

Compound 4, concentration for 50% growth inhibition: > 605000 nM
Compound 4 was reported as a limit; the forecaster's own chance of this, stated with the estimate: 85%; middle value at least 1.0-fold (0.00 log units) away from the limit.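

In this assay compound 4 gives the limit > 605000 nM as well, so its steps to compound 1, compound 2 and compound 3 cannot be read. From the compounds shown here alone, whether any group at this place gives a measured number in this assay stays open.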